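Exchanging the Quinolinyl Group of Compound 3

The source may report more compounds than this note shows. Statements on the series, on what has been measured and on what is new or still open speak of the compounds shown alone.

In an ADME assay on Vero cells (Chlorocebus sabaeus) for cytotoxicity, read by MTT assay, with a stated time of 48 h (a lower number here means that less compound is tolerated, a higher number that more compound is tolerated), compound 1 `C=C1CC[C@H]2[C@@](C)(CCC(=O)[C@@]2(C)COC(C)=O)[C@@H]1C/C=C1/C(=O)OC[C@H]1Oc1c(Cl)cc(Cl)c2cccnc12` gives 64700 nM while compound 2 `C=C1CC[C@@H]2[C@](C)(CO)[C@H](O)CC[C@@]2(C)[C@@H]1C/C=C1/C(=O)OC[C@H]1Oc1cccnc1[N+](=O)[O-]` gives 37700 nM and compound 3 `C=C1CC[C@@H]2[C@](C)(COC(C)=O)[C@H](O)CC[C@@]2(C)[C@@H]1C/C=C1/C(=O)OC[C@@H]1Oc1c(Cl)cc(Cl)c2cccnc12` gives 51900 nM as its reading. These three numbers all lie within the usual scatter of one another, so compound 3 stands level with both of the others. Compound 4 `C=C1CC[C@@H]2[C@](C)(COC(C)=O)[C@H](O)CC[C@@]2(C)[C@@H]1C/C=C1/C(=O)OC[C@@H]1Oc1cccc2ccc(C)nc12` departs from compound 3 by the exchange 2-methylquinolin-8-yl in place of 5,7-dichloroquinolin-8-yl on an oxygen on a saturated carbon with 2-methylquinolin-8-yl in place of 5,7-dichloroquinolin-8-yl on an oxygen on a saturated carbon. Among the compounds with values here, no two measured compounds differ in one place only, so this exchange has no direct precedent in the data. Compound 1 at 64700 nM and compound 2 at 37700 nM differ from compound 3 in structure yet remain within the scatter of it, so no step beyond the scatter is expected in this assay for this exchange. The estimated step of a 1.2-fold lower number from compound 3 to compound 4 (0.06 log units; within the scatter) is expected to stay within the scatter. For compound 4 the expected value is 45000 nM with an estimated range from 20000 nM to 100000 nM as the likely span.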

Compound 4, half-maximal cytotoxic concentration: 46500 nM
Compound 4: middle estimate off by 1.0-fold (0.01 log units), on the low side, and the stated range covers the measured number.
By their numbers in this assay, from the lowest: compounds 2, 4, 3 and 1 (each within the scatter of the next).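

Within the data shown here, compound 3 and compound 4 form the first pair here that differs in one place only, and in this assay the exchange of 5,7-dichloroquinolin-8-yl for 2-methylquinolin-8-yl on an oxygen on a saturated carbon gives a 1.1-fold lower number from compound 3 to compound 4 (0.05 log units; within the scatter). The earlier compounds shown here could only suggest that this position might be tolerant, whereas this pair shows directly that the chlorines can leave and a methyl group can enter, with the quinoline kept, without a reading beyond the scatter. Nothing at hand gives a reason for this level result.

On these data alone, it remains open whether the reading would stay level with a group of another kind on this oxygen, such as a quinoline bearing an amine or a carboxylic acid. As far as these compounds go, it is also open whether the same exchange would stay within the scatter on the core of compound 1.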